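This account rests on a few compounds, and the source may have more. Where it says the series, first, only, none or still open, it means among the compounds named here.

Compound 1 `c1ccc(-c2ccno2)c(OCC2=NCCN2)c1`: 100 nM in a functional assay for activation of Alpha-1B adrenergic receptor (Homo sapiens); on this read-out higher numbers stand for an effect only at larger amounts of compound and lower numbers for an effect already at smaller amounts
Compound 2 `c1ccc(-c2ccno2)c(OCc2c[nH]cn2)c1`: < 100000 nM
Compound 3 `CCN(CC)C(=O)c1ccccc1OCC1=NCCN1`: < 100000 nM

In this assay compound 1 gives 100 nM. For compound 2 the assay reports only a limit, < 100000 nM. For compound 3 likewise only a limit is reported, < 100000 nM. The change from compound 1 to compound 2 is a group of 5 heavy atoms (3 carbon, 2 nitrogen; one five-membered aromatic ring with 2 hetero atoms) in place of a group of 5 heavy atoms (3 carbon, 2 nitrogen; one five-membered non-aromatic ring with 2 hetero atoms), on a saturated chain carbon bound to an oxygen on an aromatic ring. The step that the limit leaves unreadable from compound 1 to compound 2 cannot be sized, since (the limit of < 100000 nM in this assay, at which 2 of the 3 values shown sit). How the core of compound 1 and the core of compound 3 differ is not broken down here.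

Compound 4 `CCN(CC)C(=O)c1ccccc1OCc1c[nH]cn1` has not yet been measured in this assay. It is reached from compound 3 by a group of 5 heavy atoms (3 carbon, 2 nitrogen; one five-membered aromatic ring with 2 hetero atoms) in place of a group of 5 heavy atoms (3 carbon, 2 nitrogen; one five-membered non-aromatic ring with 2 hetero atoms), on a saturated chain carbon bound to an oxygen on an aromatic ring, the same change at the same place as from compound 1 to compound 2. Compound 3 already sits at a limit, < 100000 nM. The same change gave a step that the limit leaves unreadable from compound 1 to compound 2, which ended at a limit as well. Compound 4 is therefore expected to remain at the limit, an expected step of a number no lower from compound 3 to compound 4 (the limit leaves the size open) in this assay. The estimate for compound 4 is 100000 nM, expected between 20000 nM and 300000 nM.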

Compound 4, half-maximal effective concentration: < 100000 nM
Compound 4: only a limit was reported; the forecaster's own chance of this, stated with the estimate: 85%; the middle value lies on the limit itself.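

In this assay compound 4 is reported only as a limit (< 100000 nM). Compound 3 also stands at a limit, so no step from compound 3 to compound 4 can be read: the limit of < 100000 nM in this assay, at which 3 of the 4 values shown sit.

The compounds shown leave open how far compound 2, compound 3 and compound 4 lie from that limit, and so how much the 1H-imidazol-4-yl group changes this read-out.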